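A few compounds are considered here, and "the series" means these few. Any claim that something is new, unique, unknown or untested is made for them only; others in the source may bear on it.

Three compounds share a core in which a ring amine carries a side chain ending in a methoxyphenyl group. Compound 1 `COc1ccc(CCCN2CCC(COC(c3ccccc3)c3ccc(Cl)cc3)CC2)cc1` gives 200 nM in a functional assay on cells (T-cell line, Homo sapiens) for inhibition; a higher number here means a weaker inhibitor, a lower number a stronger inhibitor. Compound 2 `COc1ccc(CCCN2CCC(C(O)CC(c3ccccc3)c3ccccc3)CC2)cc1` gives 1500 nM in this assay, and compound 3 `COc1ccccc1CCCN1CCC(COC(c2ccccc2)c2ccccc2)CC1` gives 2400 nM. Compound 3 therefore has the highest of the three numbers; its gap to compound 2 lies within the scatter, so the two cannot be ordered, while compound 1 sits well below it, beyond the scatter.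

Compound 4 `COc1ccc(/C=C/CN2CCC(COC(c3ccccc3)c3ccccc3)CC2)cc1` has not yet been measured. It differs from compound 3 in one place: 2-(4-methoxyphenyl)ethenyl in place of 2-(2-methoxyphenyl)ethyl on a saturated chain carbon bound to an amine nitrogen in a ring. For the measured compounds named here, no measured pair shows this exact change, so its size has to be guessed from the wider picture. Compound 1, which also carries a 4-methoxyphenyl group on its chain, has the lowest number in the series, and that is the only hint available; compound 1 differs from compound 4 in more than this one place, so its value is a loose guide at best. A modest downward step is expected, with a wide range on either side. For compound 4 the expected value in this assay is 700 nM, between 150 nM and 3000 nM, which is an expected step of a 3.4-fold lower number from compound 3 to compound 4 (0.54 log units; beyond the scatter).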

Compound 4, half-maximal inhibitory concentration: 4300 nM
For compound 4 the middle estimate is 6.1-fold (0.79 log units) below the measured one, and the stated range ends below it.
By their numbers in this assay, from the lowest: compound 1; then compounds 2, 3 and 4 (each within the scatter of the next, the first and the last beyond it).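

In this assay, putting 2-(4-methoxyphenyl)ethenyl in place of 2-(2-methoxyphenyl)ethyl on a saturated chain carbon bound to an amine nitrogen in a ring gives a 1.8-fold higher number from compound 3 to compound 4 (0.25 log units; within the scatter), so compound 3 and compound 4 cannot be ordered. For the compounds shown here, this is the first comparison that differs in one place only, and it shows that this one swap, which brings in a double bond outside aromatic rings and also moves from a 2-methoxyphenyl to a 4-methoxyphenyl group, gives no step beyond the scatter at this position. Nothing measured here offers an explanation for this result.

Since the two differences arrive together, they may each have no effect or may offset each other, and a 2-(4-methoxyphenyl)ethyl group on the core of compound 3 would help separate them. Also open, as far as these compounds go, is how a hydroxyl group in place of the methoxy, or a triple bond in place of the double bond, would read in this assay.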